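The compounds below may be only part of what the source reports. "The series", "measured", "known", "first", "only" and "open" are said of these compounds alone.

In a functional assay on MCF7 cells (Homo sapiens) for inhibition, read by MTT assay, with a stated time of 72 h (a lower number here means a stronger inhibitor, a higher number a weaker inhibitor), three compounds have been measured. Compound 1 `CC(C)(C)OC(=O)N1CCN(C(=S)SCc2cn(Cc3ccc(Cl)cc3)nn2)CC1` gives 2960 nM. Compound 3 `COc1ccc(Cn2cc(CSC(=S)N3CCN(C(=O)OCc4ccccc4)CC3)nn2)cc1` gives 30500 nM. Compound 2 `Cc1cc(=O)oc2cc(OCCn3cc(CSC(=S)N4CCN(C(=O)OC(C)(C)C)CC4)nn3)ccc12` gives 90400 nM, the highest of the three numbers; its nearest neighbour is compound 3 and its furthest is compound 1, and both gaps lie beyond the scatter, so compound 2 is the weakest inhibitor of the three in this assay.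

Compound 4 `CC(C)(C)OC(=O)N1CCN(C(=S)SCc2cn(CCOc3ccc4ccc(=O)oc4c3)nn2)CC1` has not been measured. It differs from compound 2 in one place: hydrogen in place of methyl on an aromatic carbon. For the measured compounds named here, no pair of measured compounds isolates such a change, so no measured step can be set beside it. The change removes a single heavy atom with no ring and no donors or acceptors, and the expected step of a 1.2-fold lower number from compound 2 to compound 4 (0.08 log units; within the scatter) is taken to lie within the scatter, with no direction favoured. Compound 4 is therefore estimated at 75000 nM, with a range from 30000 nM to 190000 nM.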

Compound 4, half-maximal inhibitory concentration: 79800 nM
Compound 4: the middle estimate sits 1.1-fold (0.03 log units) below what was measured, within the range that was stated.
By their numbers in this assay, from the lowest: compound 1; then compound 3; then compounds 4 and 2 (each within the scatter of the next).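

In this assay hydrogen in place of methyl on an aromatic carbon, opposite the ring oxygen, gives a 1.1-fold lower number from compound 2 to compound 4 (0.05 log units; within the scatter) and so no change that can be read. For the compounds shown here, this is the first measured step that isolates a single place in these compounds, and it shows that at this position the methyl can be lost without a readable effect on the number. No supporting measurement bears on this result, so it stands without an explanation.

Going by these compounds, whether a larger or different group on this same carbon, such as an ethyl group, a methoxy group, an amine or a carboxylic acid, would also leave the number in place remains open. Equally open, on these data alone, is whether the methyl would matter at the other carbons of this ring.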